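Phenoxy in place of (4-cyanophenyl)amino on a sulfonyl sulfur

This account rests on a few compounds, and the source may have more. Where it says the series, first, only, none or still open, it means among the compounds named here.

In a functional assay with Rattus norvegicus as the target (a higher number here means that more compound is needed for the effect, a lower number that less compound is needed), compound 1 (`CC1(C)C=C(n2ccccc2=O)c2cc(S(=O)(=O)N=[N+]=[N-])ccc2O1`) gives 204 nM, and compound 2 (`CC1(C)C=C(n2ccccc2=O)c2cc(S(=O)(=O)Nc3ccc(C#N)cc3)ccc2O1`) gives 1380 nM, the higher of the two numbers. For the measured compounds named here, the only measured step, a 6.8-fold higher number from compound 1 to compound 2 (0.83 log units; beyond the scatter), lies beyond the scatter and is modest in size. It replaces azido with (4-cyanophenyl)amino on a sulfonyl sulfur, the same place that changes next.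

Compound 3 (`CC1(C)C=C(n2ccccc2=O)c2cc(S(=O)(=O)Oc3ccccc3)ccc2O1`) carries phenoxy in place of (4-cyanophenyl)amino on a sulfonyl sulfur. Going by the values given here, no measured compound carries phenoxy, so the data offer no direct precedent for this group. Among the compounds with values here, the single step of a 6.8-fold higher number from compound 1 to compound 2 (0.83 log units; beyond the scatter) is therefore the only guide to how far a change at this place can move the number in this assay. Within the data shown here, compound 2 holds the higher number, and the one other group measured there, in compound 1, gives 204 nM. A moderately lower number, of smaller size than that step, is thus expected, though one step is thin support. The estimated change is a 2.1-fold lower number from compound 2 to compound 3 (0.33 log units; beyond the scatter). For compound 3 the expected value is 650 nM, with an estimated range of 170 nM to 2500 nM.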

Compound 3, half-maximal effective concentration: 13.2 nM
Estimate against measurement, compound 3: 49-fold (1.69 log units) above; measured number outside the range, below it.
By their numbers in this assay, from the lowest: compound 3; then compound 1; then compound 2.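

In this assay, a change on the sulfonyl sulfur can move the number much further than the earlier step showed: a 100-fold lower number from compound 2 to compound 3 (2.02 log units; beyond the scatter), and phenoxy also improves on azido, with a 15-fold lower number from compound 1 to compound 3 (1.19 log units; beyond the scatter). Compound 3 therefore holds the lowest number of the three, and both its steps lie beyond the scatter, while (4-cyanophenyl)amino and phenoxy, each with a six-membered aromatic ring of carbon only, stand at opposite ends of the order, so the presence of such a ring does not by itself set the number among these compounds. Nothing available here accounts for the size of these differences.

The step from compound 2 to compound 3 changes several features at once: the nitrile leaves, the hydrogen-bond donor leaves and an oxygen replaces the nitrogen attached to the sulfonyl sulfur, so the compounds shown cannot assign the drop to any one of these. A plain phenylamino group would show what the nitrile contributes, a phenoxy group carrying a nitrile would test the same feature from the other side, and a small methoxy group would show whether the aromatic ring is needed at all.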